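Methyl on the Phenol Oxygen: Expecting Compound 4

This account rests on a few compounds, and the source may have more. Where it says the series, first, only, none or still open, it means among the compounds named here.

Measured so far in a functional assay on 786-0 cells (Homo sapiens) for inhibition, read by sulforhodamine B assay, with a stated time of 48 h; on this read-out higher numbers stand for weaker inhibition of growth and lower numbers for stronger inhibition of growth:
- compound 1 `CC1(/C=C/c2cccc(O)c2)C=CC(=O)O1` gives 196000 nM
- compound 2 `CC1(/C=C/c2ccc(O)cc2)C=CC(=O)O1` gives 143000 nM
- compound 3 `COc1cccc(/C=C/C2(C)C=CC(=O)O2)c1` gives 70000 nM

Compound 1 and compound 2 share the same atoms joined differently; the difference between the two cores is not broken down here. Their two values in this assay lie within the usual scatter of each other, so nothing can be said about which is stronger.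

Compound 3 is compound 1 with one change, (methyl in place of hydrogen on an oxygen on an aromatic ring), and this single change produced a 2.8-fold lower number from compound 1 to compound 3 (0.45 log units; beyond the scatter). Compound 4 `COc1ccc(/C=C/C2(C)C=CC(=O)O2)cc1`, still to be measured, is compound 2 with the same change, (methyl in place of hydrogen on an oxygen on an aromatic ring), at a place described in the same words for both pairs.

Among the measured compounds shown here, with only one measured example of this change, the expectation for compound 4 rests on that single step. If the change behaves on compound 2 as it did on compound 1, compound 4 is expected to show a step of about a 2.9-fold lower number from compound 2 to compound 4 (0.46 log units; beyond the scatter) in this assay, comparable in size to the earlier one. Because compound 2 starts from 143000 nM, compound 4 is estimated at about 50000 nM, with a plausible range from 25000 nM to 140000 nM. Whether compound 4 indeed falls there is what the measurement will tell.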

Compound 4, concentration for total growth inhibition: > 1000000 nM
Compound 4: only a limit was reported (the forecaster's own chance of this, stated with the estimate: 10%); at least 20-fold (1.30 log units) between middle value and limit.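

The same change, methyl in place of hydrogen on an oxygen on an aromatic ring, does not carry over from one core to the other in this assay, where on the core of compound 2 it gives an at least 6.9-fold higher number from compound 2 to compound 4 (0.84 log units; beyond the scatter), in the opposite direction to the earlier step: the same change on two cores in this assay, a 2.8-fold lower number (0.45 log units; beyond the scatter) from compound 1 to compound 3 and an at least 6.9-fold higher number (0.84 log units; beyond the scatter) from compound 2 to compound 4, at least 19-fold (1.29 log units) apart, beyond the scatter of two such steps
On these data alone, compound 4 gives > 1000000 nM, which is a limit of the assay and not a number, so the true size of this step remains unknown. These two pairs show that the outcome of this change in this series can differ from one core to another, even in direction, but they do not show why, and two pairs give no rule for predicting it on any further core.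

The compounds shown carry only hydroxy or methoxy on the aromatic ring, so it remains open how an amine, a carboxylic acid or a longer chain such as ethoxy would behave at the same place on either core. As far as these compounds go, it also remains open whether the opposite steps seen on these two cores would appear again on other cell lines.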